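The compounds below may be only part of what the source reports. "The series", "measured", "known", "first", "only" and "open" are said of these compounds alone.

Compound 1, `Cc1cn([C@@H]2O[C@H](CO[Si](C)(C)C(C)(C)C)[C@@]3(OS(=O)(=O)C=C3NCC(=O)C(=O)N3CCC3)[C@H]2O[Si](C)(C)C(C)(C)C)c(=O)n(C)c1=O`: 65000 nM
Compound 2, `Cc1cn([C@@H]2O[C@H](CO[Si](C)(C)C(C)(C)C)[C@@]3(OS(=O)(=O)C=C3NCCC(=O)O)[C@H]2O[Si](C)(C)C(C)(C)C)c(=O)n(C)c1=O`: 80000 nM

In a functional assay on HEL cells (Homo sapiens) for cytotoxicity, read by microscopy (on this read-out lower numbers stand for higher toxicity in this test and higher numbers for lower toxicity in this test), compound 1 gives 65000 nM, and compound 2 gives 80000 nM. Among the compounds with values here, compound 2 stands next to compound 1, the only other compound measured here, and the two numbers are within the usual scatter of each other, as the step of a 1.2-fold higher number from compound 1 to compound 2 (0.09 log units; within the scatter) shows. Compound 3, `COC(=O)CCNC1=CS(=O)(=O)O[C@@]12[C@@H](CO[Si](C)(C)C(C)(C)C)O[C@@H](n1cc(C)c(=O)n(C)c1=O)[C@@H]2O[Si](C)(C)C(C)(C)C`, differs from compound 2 in one place: methyl in place of hydrogen on an oxygen next to a carbonyl group. Within the data shown here, the one measured step, a 1.2-fold higher number from compound 1 to compound 2 (0.09 log units; within the scatter), swapped a much larger piece on the same chain and still moved the number only within the scatter, so it bears on the present change only loosely and gives no sign that this chain end drives toxicity. The step of no change at the digits printed from compound 2 to compound 3 (within the scatter) is therefore expected to stay within the scatter, in no particular direction. Compound 3 is estimated at 80000 nM, with a likely range from 40000 nM to 160000 nM.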

Compound 3, minimum cytotoxic concentration: >= 400000 nM
Compound 3: a limit, no number (the forecaster's own chance of this, stated with the estimate: 25%); middle value at least 5.0-fold (0.69 log units) from the limit.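

In this assay compound 3 gives >= 400000 nM, which is a limit of the assay and not a number. Putting a single methyl on the oxygen, which turns carboxy into methoxycarbonyl, gives an at least 5.0-fold higher number from compound 2 to compound 3 (0.69 log units; beyond the scatter), so the end of this chain can shift the read-out, something a 1.2-fold higher number from compound 1 to compound 2 (0.09 log units; within the scatter) had not revealed. The comparison with the azetidine-bearing end gives an at least 6.1-fold higher number from compound 1 to compound 3 (0.78 log units; beyond the scatter), and since higher numbers here stand for lower toxicity in this test, the methyl ester end is the least toxic of the three.

From the compounds shown here alone, how far the number for compound 3 lies past its limit stays open. Going by these compounds, it is also open whether an ethyl ester, a primary amide or a longer chain ending in methoxycarbonyl would keep the number this high.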